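Methoxy on the fused ring of compound 1

The source may report more compounds than this note shows. Statements on the series, on what has been measured and on what is new or still open speak of the compounds shown alone.

For the measured compounds named here, compound 1 `CCOC(=O)c1c(-c2cc3ccccc3oc2=O)nn(-c2ccccc2)c1C(=O)OCC` gives 57000 nM in a functional assay on DU-145 cells (Homo sapiens) for cytotoxicity, read by MTT assay, with a stated time of 48 h (on this read-out lower numbers stand for stronger inhibition and higher numbers for weaker inhibition), the highest of the two numbers measured so far; compound 2 `CCOC(=O)c1c(-c2cc3ccccc3oc2=O)nn(-c2ccc(C)c(C)c2)c1C(=O)OCC` gives 40000 nM in this assay, and the only step between measured compounds is a 1.4-fold lower number from compound 1 to compound 2 (0.15 log units; within the scatter). Compound 3 `CCOC(=O)c1c(-c2cc3cc(OC)ccc3oc2=O)nn(-c2ccccc2)c1C(=O)OCC` carries methoxy in place of hydrogen on an aromatic carbon. Going by the values given here, that one measured step alters the group on the aromatic nitrogen and says nothing about the fused ring, so no measured step bears on the place changed in compound 3. Compound 3 is therefore expected to show no step beyond the scatter, no change at the digits printed from compound 1 to compound 3 (within the scatter), with an estimate of 57000 nM and a range from 20000 nM to 150000 nM.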

Compound 3, half-maximal inhibitory concentration: 27000 nM
Beside the measured number, compound 3's estimate is 2.1-fold (0.32 log units) above it; low and high end bracket the measured number.
By their numbers in this assay, from the lowest: compounds 3, 2 and 1 (each within the scatter of the next, the first and the last beyond it).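

In this assay, methoxy in place of hydrogen on an aromatic carbon of the fused ring gives a 2.1-fold lower number from compound 1 to compound 3 (0.32 log units; beyond the scatter), so this position of the core of compound 1 responds to substitution, if only modestly. For the compounds shown here, this is the first step beyond the scatter; the earlier step, on the aromatic nitrogen, stayed within it. Nothing at hand accounts for the step.

On these data alone, whether a hydroxyl, an amine or a longer alkoxy chain at this place would do the same remains open. Also open, as far as these compounds go, is whether methoxy would act alike with the 3,4-dimethylphenyl of compound 2.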